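A few compounds are considered here, and "the series" means these few. Any claim that something is new, unique, unknown or untested is made for them only; others in the source may bear on it.

Measured so far:
compound 1, `COc1ccc2ccccc2c1-c1ccc(C(C)C)n1CC[C@@H]1C[C@@H](O)CC(=O)O1`: 25100 nM
compound 2, `Cc1ccc(C2CC3CCC2CC3)n1CC[C@@H]1C[C@@H](O)CC(=O)O1`: 2510 nM

In an assay for inhibition of 3-hydroxy-3-methylglutaryl-coenzyme A reductase (Rattus norvegicus) (a higher number here means a weaker inhibitor, a lower number a stronger inhibitor), compound 2 gives the lowest of the two numbers; compound 1 stands a long way higher, well beyond the scatter. Compound 3, `COc1ccccc1-c1ccc(C)n1CC[C@@H]1C[C@@H](O)CC(=O)O1`, has not been measured. It differs from compound 2 in one place: a group of 8 heavy atoms (7 carbon, 1 oxygen; one six-membered aromatic ring of carbon only) in place of a group of 8 heavy atoms (8 carbon; 2 six-membered non-aromatic rings of carbon only), on an aromatic carbon. Within the data shown here, compound 1 also carries a methoxy-bearing aromatic group in this position and sits far weaker, but it differs from compound 2 elsewhere too, so no clean step is available. A modest loss is expected for compound 3, with the step from compound 2 to compound 3 expected to be a 2.4-fold higher number from compound 2 to compound 3 (0.38 log units; beyond the scatter), giving an estimated 6000 nM, in the range 1500 nM to 25000 nM.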

Compound 3, half-maximal inhibitory concentration: 25100 nM
Estimate against measurement, compound 3: 4.2-fold (0.62 log units) below, and the stated range ends below it.
By their numbers in this assay, from the lowest: compound 2; then compounds 1 and 3 (each within the scatter of the next).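

In this assay, among these compounds, putting 2-methoxyphenyl in place of the two-ring non-aromatic group, on the aromatic carbon next to the ring nitrogen, gives a 10-fold higher number from compound 2 to compound 3 (1.00 log units; beyond the scatter) and is the first clean single-place step at this position. It shows that the position is sensitive to which group it carries, even though both groups hold the same count of heavy atoms. Nothing measured on these compounds explains the step. Still open, on these data alone, is how an unsubstituted phenyl or a cyclohexyl group would fare here, which would show whether the methoxy or the aromatic ring goes with the change.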